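Fluoro for hydrogen on the core of compound 2

This account rests on a few compounds, and the source may have more. Where it says the series, first, only, none or still open, it means among the compounds named here.

Measured so far:
compound 1, `COc1ccc2c(c1)OC(c1ccc(C)cc1)CC2=O`, 550 nM
compound 2, `Cc1ccc(C2CC(=O)c3ccccc3O2)cc1`, 2070 nM

Both values come from an in vitro assay on BTI-TN-5B1-4 cells for inhibition of Amine oxidase [flavin-containing] B (Homo sapiens); on this read-out higher numbers stand for weaker inhibition and lower numbers for stronger inhibition. Among the two numbers, compound 2 stands highest; its only neighbour is compound 1, and the step of a 3.8-fold higher number from compound 1 to compound 2 (0.58 log units; beyond the scatter) lies beyond the scatter. That single step shows that a group on the fused ring of the shared core can shift the number, although methoxy and fluoro are different groups sitting at different places on that ring.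

Compound 3, `Cc1ccc(C2CC(=O)c3ccc(F)cc3O2)cc1`, has not been measured. It differs from compound 2 by fluoro in place of hydrogen on an aromatic carbon. For the measured compounds named here, no measured step involves a fluoro, so the step from compound 2 to compound 1 gives only a loose hint. Going by these compounds, because of that step (a 3.8-fold higher number from compound 1 to compound 2 (0.58 log units; beyond the scatter)) a change on this ring is expected to matter somewhat, but the direction for fluoro remains open, so the expected step of a 1.5-fold lower number from compound 2 to compound 3 (0.17 log units; within the scatter) is modest and uncertain. The estimate for compound 3 in this assay is 1400 nM, with a range from 500 nM to 4000 nM.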

Compound 3, half-maximal inhibitory concentration: 160 nM
Compound 3: middle estimate off by 8.8-fold (0.94 log units), on the high side; measured number below the stated range.
By their numbers in this assay, from the lowest: compound 3; then compound 1; then compound 2.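

Putting fluoro in place of hydrogen on this aromatic carbon of the shared core gives a 13-fold lower number from compound 2 to compound 3 (1.11 log units; beyond the scatter) in this assay, so a single added atom here settles the direction that the earlier pair left open and produces a large gain in inhibition. Fluoro also does better than the larger methoxy group, with a 3.4-fold lower number from compound 1 to compound 3 (0.54 log units; beyond the scatter), so among the three groups seen on this ring the number falls from hydrogen through methoxy to fluoro, and compound 3 is the strongest inhibitor of the three. Nothing available here explains why fluoro has this effect.

The three compounds leave open whether the trend continues to other groups on this ring, such as chloro, an amine, a carboxylic acid or a longer chain like ethoxy, and a three-point order cannot predict where those would fall. It is also open whether fluoro would bring a similar gain on another carbon of the same ring, or whether the gain depends on the methyl group on the other aromatic ring of these compounds.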